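Methyl in Place of Chloro: an Expected Weak Inhibitor

A few compounds are considered here, and "the series" means these few. Any claim that something is new, unique, unknown or untested is made for them only; others in the source may bear on it.

Measured compounds:
compound 1 `O=c1c(Cc2coc3cccc(OCC4CCCCC4)c3c2=O)coc2cc(Cl)ccc12` — > 10000 nM
compound 2 `CC(C)CCOc1cccc2occ(Cc3coc4ccccc4c3=O)c(=O)c12` — > 10000 nM

In a functional assay on MDA-MB-231 cells (Homo sapiens) for antiproliferative activity, read by XTT assay (on this read-out higher numbers stand for weaker inhibition and lower numbers for stronger inhibition), compound 1 gives only a limit, > 10000 nM, and not a number. Compound 2 likewise reaches only a limit, > 10000 nM. Both measured results sit together at the limit of > 10000 nM in this assay, at which 2 of the 2 values shown sit, so compound 1 cannot be placed on a potency scale. Compound 3 `Cc1ccc2c(=O)c(Cc3coc4cccc(OCC5CCCCC5)c4c3=O)coc2c1` differs from compound 1 by methyl in place of chloro on an aromatic carbon. Going by the values given here, no step between measured compounds is available to guide the size of this change, so no shift beyond the scatter is expected in this assay. Compound 3 is expected to give 15000 nM, between 5000 nM and 50000 nM, most likely again only a limit. The expected step is a step that the limit leaves unreadable from compound 1 to compound 3.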

Compound 3, half-maximal inhibitory concentration: 3320 nM
Beside the measured number, compound 3's estimate is 4.5-fold (0.65 log units) above it; measured number below the stated range.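

In this assay, methyl in place of chloro on an aromatic carbon gives an at least 3.0-fold lower number from compound 1 to compound 3 (0.47 log units; beyond the scatter), the first sign that this position of the shared core can change the read-out. Compound 1 gives only a limit, so the full size of this step cannot be read: the limit of > 10000 nM in this assay, at which 2 of the 3 values shown sit.

The compounds shown leave open whether the lower number is tied to the methyl itself or to the absence of chloro. From the compounds shown here alone, how an amine, a methoxy group or a longer chain would behave at this position also remains unknown.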